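Inverting one chain stereocentre of compound 2

The source may hold more compounds than are shown below. What is called first, only, known or untested is meant among the compounds shown, and "the series" means these compounds.

Compound 2 `CCCCC[C@@H](C[C@H](O)C[C@H]1CC=CC(=O)O1)OC` is the starting point for this step. Going by the values given here, in a functional assay on A2780 cells (Homo sapiens) for cytotoxicity, read by MTT assay, with a stated time of 24 h (on this read-out lower numbers stand for stronger inhibition and higher numbers for weaker inhibition), compound 2 gives 53700 nM and compound 1 `CCCCC[C@H](C[C@@H](O)C[C@@H]1CC=CC(=O)O1)OC` gives 54500 nM, so compound 2 sits level with the only other measured value. Among the compounds with values here, the one measured step, a 1.0-fold lower number from compound 1 to compound 2 (0.01 log units; within the scatter), lies within the scatter. The relevant observation for this pair is the fact that compounds 1 and 2 differ only in the configuration as drawn, and here all stereocentres are inverted together, giving mirror images.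

Compound 3 `CCCCC[C@H](C[C@H](O)C[C@H]1CC=CC(=O)O1)OC` changes less: the two compounds have the same atoms and bonds and differ only in configuration as drawn: 1 of 3 stereo elements differ; a stereocentre at a saturated chain carbon is drawn S in compound 2 and R in compound 3. Nothing leaves and nothing enters. The measured step bears on this change only in part, since inverting all stereocentres is not the same as inverting one, and compound 3 is not tested by the mirror-image comparison. Within the data shown here, still, the only configurational change measured, a 1.0-fold lower number from compound 1 to compound 2 (0.01 log units; within the scatter), gave no shift beyond the scatter, so no step beyond the scatter is expected in this assay, and no direction is favoured. The expected change is a 1.1-fold lower number from compound 2 to compound 3 (0.03 log units; within the scatter). Compound 3 is estimated at 50000 nM, with an expected range of 22000 nM to 100000 nM.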

Compound 3, half-maximal inhibitory concentration: 44000 nM
Compound 3: middle estimate off by 1.1-fold (0.06 log units), on the high side; low and high end bracket the measured number.
By their numbers in this assay, from the lowest: compounds 3, 2 and 1 (each within the scatter of the next).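

In this assay, going by these compounds alone, the step of a 1.2-fold lower number from compound 2 to compound 3 (0.09 log units; within the scatter) is the first reading of a single inverted chain stereocentre, whereas the earlier pair inverted all stereocentres together, and the change at this carbon does not separate the two values: the fact that compounds 2 and 3 differ only in the configuration as drawn. A change at two of the three stereo elements gives the same picture, with a 1.2-fold lower number from compound 1 to compound 3 (0.09 log units; within the scatter): the fact that compounds 1 and 3 differ only in the configuration as drawn. Compounds 1, 2 and 3 now span changes at one, two and all three stereo elements, and none of these comparisons moves beyond the scatter in this assay, so within these compounds the drawn configuration at this chain carbon shows no readable effect on the number.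

What inversion of the saturated ring carbon alone would do remains open, as no pair shown isolates that stereocentre. Also open, on these data alone, is whether this insensitivity to configuration would hold with an amine, a carboxylic acid or a longer chain on the shared core, or in any read-out other than this one.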